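From 2,3-dichlorophenyl to 2,5-dimethoxyphenyl on the chain

A few compounds are considered here, and "the series" means these few. Any claim that something is new, unique, unknown or untested is made for them only; others in the source may bear on it.

In a functional assay on MCF7 cells (Homo sapiens) for cytotoxicity, read by MTT assay, with a stated time of 72 h (a lower number here means a stronger inhibitor, a higher number a weaker inhibitor), compound 1 (`COc1cc2ncnc(Nc3ccc(F)c(Cl)c3)c2cc1NC(=O)/C=C/c1ccc(F)cc1Cl`) is recorded as "not active" (no number reported) with no number given. Compound 2 (`O=C(/C=C/c1cccc(Cl)c1Cl)Nc1cc2c(Nc3ccc(F)c(Cl)c3)ncnc2cc1O[C@H]1CCOC1`) gives 30100 nM in the same test, and compound 3 (`COc1cc2ncnc(Nc3ccc(F)c(Cl)c3)c2cc1NC(=O)/C=C/c1ccccc1[N+](=O)[O-]`) gives 36500 nM there. Those two numbers lie within the scatter of each other, so compound 2 cannot be ranked against compound 3. Compound 4 (`COc1ccc(OC)c(/C=C/C(=O)Nc2cc3c(Nc4ccc(F)c(Cl)c4)ncnc3cc2O[C@H]2CCOC2)c1`) has not yet been measured. It differs from compound 2 by one change (2,5-dimethoxyphenyl in place of 2,3-dichlorophenyl on a double-bonded chain carbon bound to a double-bonded chain carbon), with 2,5-dimethoxyphenyl in place of 2,3-dichlorophenyl on a double-bonded chain carbon bound to a double-bonded chain carbon. Going by the values given here, no measured step shows what such a change does, so no shift beyond the scatter is expected, in either direction. The expected step is a 1.1-fold higher number from compound 2 to compound 4 (0.03 log units; within the scatter) in this assay and stays within the scatter. This expectation leans on compound 3 at 36500 nM (within the scatter of compound 2), while compound 1 goes against it, so a result without a number remains possible. For compound 4 the estimated value is 32000 nM (12000 nM to 80000 nM).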

Compound 4, half-maximal inhibitory concentration: 36300 nM
Compound 4: middle estimate off by 1.1-fold (0.05 log units), on the low side, and the stated range covers the measured number.
By their numbers in this assay, from the lowest: compounds 2, 4 and 3 (each within the scatter of the next).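

In this assay, going by these compounds alone, the first measured step at this position reads a 1.2-fold higher number from compound 2 to compound 4 (0.08 log units; within the scatter). Replacing 2,3-dichlorophenyl with 2,5-dimethoxyphenyl on a double-bonded chain carbon bound to a double-bonded chain carbon exchanges 2 chlorine atoms for two methoxy groups and adds 2 hydrogen-bond acceptors, yet the two numbers cannot be told apart. No measurement shown accounts for this result.

As far as these compounds go, it remains open whether any group at this place would shift the number beyond the scatter, such as an amine or a carboxylic acid on the phenyl ring, or a longer chain in place of the ethenyl link. From the compounds shown here alone, it is equally open whether the same change would read the same way on the core of compound 3.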